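Notes on removing 4-methoxybenzyl from compound 3

The source may hold more compounds than are shown below. What is called first, only, known or untested is meant among the compounds shown, and "the series" means these compounds.

In a functional assay on U-937 cells (Homo sapiens) for inhibition, read by MTT assay, with a stated time of 24 h (on this read-out lower numbers stand for stronger inhibition of growth and higher numbers for weaker inhibition of growth), compound 1 (`COc1ccc(Cn2ncc3c2NC(=O)CC(c2cccc(NC(=O)Nc4ccc(Cl)cc4)c2)=N3)cc1`) gives 580 nM. Compound 3 (`COc1ccc(Cn2ncc3c2NC(=O)CC(c2cccc(NC(=O)Nc4ccc(Cl)c(Cl)c4)c2)=N3)cc1`) gives 14900 nM, the higher of the two numeric values in the series. Chloro in place of hydrogen on an aromatic carbon accounts for a 26-fold higher number from compound 1 to compound 3 (1.41 log units; beyond the scatter). Compound 2 (`O=C1CC(c2cccc(NC(=O)Nc3ccc(Cl)cc3)c2)=Nc2cn[nH]c2N1`) gives > 30000 nM, and this value is a limit. To be kept in view for what follows is the limit of > 30000 nM in this assay, at which 1 of the 3 values shown sits.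

Compound 4 (`O=C1CC(c2cccc(NC(=O)Nc3ccc(Cl)c(Cl)c3)c2)=Nc2cn[nH]c2N1`) is reached from compound 3 through (hydrogen in place of 4-methoxybenzyl on an aromatic nitrogen). The group is replaced on an aromatic nitrogen of a five-membered aromatic ring with 2 nitrogen. Among the measured compounds shown here, one measured step bears directly on this change: an at least 51-fold higher number from compound 1 to compound 2 (1.71 log units; beyond the scatter), a large step that ends at the limit. The chloro step matters only in setting the starting point. A step to a higher number is therefore expected in this assay. Its readable size is expected to be smaller than the earlier one because compound 3 gives 14900 nM to begin with. Compound 4 is likely to be reported as a limit. The estimated change is a 2.7-fold higher number from compound 3 to compound 4 (0.43 log units; beyond the scatter). For compound 4 the expected value is 40000 nM, with an estimated range of 18000 nM to 90000 nM.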

Compound 4, concentration for 50% growth inhibition: > 30000 nM
Compound 4: only a limit was reported; the forecaster's own chance of this, stated with the estimate: 85%; the middle value lies beyond the limit too.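

Hydrogen in place of 4-methoxybenzyl on the aromatic nitrogen gives an at least 2.0-fold higher number from compound 3 to compound 4 (0.30 log units; that floor lies within the scatter) in this assay, so the second case of this change yields only a floor, and that floor does not by itself separate the pair. Both compounds that carry hydrogen on this nitrogen now sit at the reported limit, so neither gives a number, and the loss of 4-methoxybenzyl is never seen to leave measurable growth inhibition on either core: the limit of > 30000 nM in this assay, at which 2 of the 4 values shown sit. The larger floor on the first core and the smaller floor here therefore cannot be ranked: the same change on two cores in this assay, an at least 51-fold higher number (1.71 log units; beyond the scatter) from compound 1 to compound 2 and an at least 2.0-fold higher number (0.30 log units; that floor lies within the scatter) from compound 3 to compound 4; the limit leaves it open whether they differ.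

Chloro in place of hydrogen on an aromatic carbon, a large step with 4-methoxybenzyl present, cannot be read between compound 2 and compound 4, so whether it carries over to the compounds with hydrogen on this nitrogen stays open. Also open, as far as these compounds go, is how much of the 4-methoxybenzyl group is needed, since a plain benzyl, a methyl or a longer alkyl chain on the same nitrogen would show whether a numeric value returns in this assay.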